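Working notes: methoxy for hydrogen, compound 2 to compound 3

A few compounds are considered here, and "the series" means these few. Any claim that something is new, unique, unknown or untested is made for them only; others in the source may bear on it.

Going by the values given here, compound 2 `COc1ccc(C(=O)/C=C/c2cc(-c3cc(OC)c(OC)c(OC)c3)n[nH]2)cc1OC` gives 86% in a functional assay on UO-31 cells (Homo sapiens) for cytotoxicity, read by sulforhodamine B assay, with a stated time of 48 h, tested at 0.01 uM (a lower number here means a stronger effect, a higher number a weaker effect of the compound at the concentration tested), and stands lowest of the two numbers measured so far. Among the compounds with values here, its nearest neighbour is compound 1 `COc1cc(-c2cc(/C=C/C(=O)c3ccc(N)cc3)[nH]n2)cc(OC)c1OC`, which in this assay gives 91%; the only measured step, a number 5 percentage points lower from compound 1 to compound 2 (within the scatter), lies within the scatter, so the two compounds cannot be placed in any order on these numbers.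

Compound 3 `COc1cc(C(=O)/C=C/c2cc(-c3cc(OC)c(OC)c(OC)c3)n[nH]2)cc(OC)c1OC` is the next member. Compared with compound 2 the difference is methoxy in place of hydrogen on an aromatic carbon. Within the data shown here, the single measured step, a number 5 percentage points lower from compound 1 to compound 2 (within the scatter), changed the group on the carbonyl carbon rather than a substituent on the six-membered aromatic ring of carbon only, so it bears on the present change only in a general way: a full swap of the group on the carbonyl carbon moved the read-out by a small amount within the scatter. On that basis no step beyond the scatter is expected for the added methoxy, and the expected step is a number 2 percentage points higher from compound 2 to compound 3 (within the scatter). Compound 3 is therefore estimated at 88% in this assay, with a range from 75% to 98%.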

Compound 3, a percentage reported as activity, at one concentration (the size of the read-out at that concentration, not a potency): 90%
Compound 3: the middle estimate sits 2 percentage points below what was measured; the measured number falls inside the stated range.
By their numbers in this assay, from the lowest: compounds 2, 3 and 1 (each within the scatter of the next).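

Going by these compounds alone, until now the only measured step swapped the whole group on the carbonyl carbon. This step adds a single methoxy to the six-membered aromatic ring of carbon only, on a carbon ortho to a methoxy group and meta to a large group, and in this assay it gives a number 4 percentage points higher from compound 2 to compound 3 (within the scatter), so the added methoxy produces no step beyond the scatter. With compound 3 at 90% in this read-out, where a lower number means a stronger effect, the change leaves compound 3 and compound 2 unordered at the one concentration tested. No measurement at hand gives a cause for this result.

The compounds shown leave open how an amine, a carboxylic acid or a longer chain such as ethoxy would read at this same ring position, where only hydrogen and methoxy appear so far. The read-out comes from one low concentration, and they also leave open whether compound 2 and compound 3 would separate by a stronger or weaker effect at a higher concentration.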